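Swapping hydroxy for anilino on compound 1

This account rests on a few compounds, and the source may have more. Where it says the series, first, only, none or still open, it means among the compounds named here.

compound 1 `CC(=O)SCCC(CCCCC(=O)O)SC(C)=O`: 1.61%
compound 2 `O=C(CCCCC(S)CCS)Nc1ccc(Cl)cc1`: "not active" (no number reported)
compound 3 `COc1ccc(NC(=O)CCCCC(S)CCS)cc1`: 4.14%

In a functional assay on HO8910 cells (Homo sapiens) for inhibition, read by MTT assay, with a stated time of 24 h, tested at 10 ug/mL (a lower number here means less inhibition of growth, a higher number more inhibition of growth at the concentration tested), compound 1 gives 1.61% as its reading, which lies within the usual scatter of compound 3, while compound 2 has no number at all. Compound 4 `CC(=O)SCCC(CCCCC(=O)Nc1ccccc1)SC(C)=O` is compound 1 with one change anilino in place of hydroxy on a carbonyl carbon. Going by the values given here, no measured pair shows this change directly, so its size is uncertain. Compound 3, which also has a six-membered aromatic ring, gives 4.14% in this assay, so only a small rise, probably none beyond the scatter, is expected. For compound 4 the estimated value is 7% within an expected range of 0% to 22% in this assay. That estimate means a number 5.4 percentage points higher from compound 1 to compound 4 (within the scatter) as the expected step.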

Compound 4, percent growth inhibition at one concentration: 3.2%
Compound 4: middle estimate off by 3.8 percentage points, on the high side, and the stated range covers the measured number.
By their numbers in this assay, from the lowest: compounds 1, 4 and 3 (each within the scatter of the next).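

Anilino in place of hydroxy on a carbonyl carbon gives a number 1.6 percentage points higher from compound 1 to compound 4 (within the scatter) in this assay, the first measured pair for this change. At this place on the core of compound 1, then, swapping one heavy atom for seven, including a six-membered aromatic ring, shifts growth inhibition by no more than the scatter at the concentration tested. Nothing available offers an explanation for this result. From the compounds shown here alone, it remains open whether a benzylamino or morpholino group on this carbonyl carbon would give a reading beyond the scatter.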